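Swapping a methoxyphenyl for a methylphenyl on the chain

The source may hold more compounds than are shown below. What is called first, only, known or untested is meant among the compounds shown, and "the series" means these compounds.

Compound 2 `COC1=C(C)C(=O)/C(=C(O)/C=C/c2ccccc2OC)C(=O)C1(C)C` and compound 1 `COC1=C(C)C(=O)/C(=C(O)/C=C/c2cccc(OC)c2)C(=O)C1(C)C` share one core and differ only in the aryl group on the chain. In a functional assay on HUVEC cells (Homo sapiens) for cytotoxicity (a higher number here means that more compound is needed for the effect, a lower number that less compound is needed), compound 1 gives 1.6 ug/mL, and compound 2 gives 1.7 ug/mL; the two numbers sit within the scatter of each other, as the step of a 1.1-fold higher number from compound 1 to compound 2 (0.03 log units; within the scatter) shows. Compound 3 `COC1=C(C)C(=O)/C(=C(O)/C=C/c2ccc(C)cc2)C(=O)C1(C)C` differs from compound 2 as follows: 4-methylphenyl in place of 2-methoxyphenyl on a double-bonded chain carbon bound to a double-bonded chain carbon. Among the compounds with values here, only that one step bears on this change, and it was flat, so for compound 3 a step of about no change at the digits printed from compound 2 to compound 3 (within the scatter) is expected, with no clear direction. Compound 3 is therefore estimated at 1.7 ug/mL, within a range of 0.8 ug/mL to 3.5 ug/mL.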

Compound 3, concentration for half-maximal effect: 2.4 ug/mL
Estimate against measurement, compound 3: 1.4-fold (0.15 log units) below, within the range that was stated.
By their numbers in this assay, from the lowest: compounds 1, 2 and 3 (each within the scatter of the next).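

In this assay, the new change goes beyond moving a methoxy group around the ring, and the steps stay small: a 1.4-fold higher number from compound 2 to compound 3 (0.15 log units; within the scatter) and a 1.5-fold higher number from compound 1 to compound 3 (0.18 log units; within the scatter). At this place on the chain, 4-methylphenyl, which has no hydrogen-bond acceptor, therefore reads the same as either methoxyphenyl within the scatter. Nothing available explains this flat result. The compounds shown leave open whether a much larger step would follow from an amine or a carboxylic acid on the phenyl ring. They also leave open what happens when a simple methyl group replaces the whole aryl group.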